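The compounds below may be only part of what the source reports. "The series", "measured", "known", "first", "only" and "open" are said of these compounds alone.

Compound 1 `N#C/C(=C\c1ccc[nH]1)C(=O)NCc1ccc(Cl)c(Cl)c1` — in a functional assay on MIA cells (Homo sapiens) for inhibition, read by MTT assay, with a stated time of 72 h (on this read-out lower numbers stand for stronger inhibition of growth and higher numbers for weaker inhibition of growth), compound 1 gives the limit > 50000 nM.
Compound 2 `COc1ccc(CNC(=O)/C(C#N)=C/c2ccc(C)o2)cc1` — in this assay compound 2 gives 51000 nM.
Compound 3 `COc1ccc(CNC(=O)/C(C#N)=C/c2cccc3ccccc23)cc1` — in this assay compound 3 gives 15000 nM.

The value of compound 1 is a limit of the assay and not a number, (the limit of > 50000 nM in this assay, at which 1 of the 3 values shown sits). Of the two numbers shown, compound 3 holds the lower one, and its gap to compound 2 lies beyond the usual scatter of this kind of measurement.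

Compound 4 `N#C/C(=C\c1cccc2ccccc12)C(=O)NCc1ccc(Cl)c(Cl)c1` differs from compound 3 in one place: 3,4-dichlorophenyl in place of 4-methoxyphenyl on a saturated chain carbon bound to an amide-type nitrogen. Among the measured compounds shown here, no pair of measured compounds differs by this exchange alone, so no measured step carries it. Compound 1 does bear the 3,4-dichlorophenyl group, but it also bears a different group at the other end of the shared core and sits at a limit, so its value says nothing about this exchange on its own.

The step from compound 3 to compound 4 in this assay is expected to be small, a 1.3-fold higher number from compound 3 to compound 4 (0.12 log units; within the scatter), and not beyond the scatter in either direction. Compound 4 is therefore estimated to give 20000 nM, with a range from 7000 nM to 60000 nM.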

Compound 4, concentration for 50% growth inhibition: 8000 nM
Compound 4: middle estimate off by 2.5-fold (0.40 log units), on the high side; the range from low to high includes it.
By their numbers in this assay, from the lowest: compounds 4 and 3 (each within the scatter of the next); then compound 2.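

Among the compounds shown here, this is the first measured step at this position, on a saturated chain carbon bound to an amide-type nitrogen: in this assay the exchange of 4-methoxyphenyl for 3,4-dichlorophenyl brings a 1.9-fold lower number from compound 3 to compound 4 (0.27 log units; within the scatter) and so gives no separation between the two groups. On this shared core the position accepts either group, and neither can be ranked over the other on this read-out. Nothing measured here offers a reason for this outcome.

As far as these compounds go, whether a carboxylic acid or an amine in place of these phenyl groups, or a longer chain at this position, would shift the number beyond the scatter remains open. Also open, from the compounds shown here alone, is whether the same exchange behaves alike on the other cores, none of which appears here with both groups.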